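Swapping the Ring on the Carbonyl Carbon

The compounds below may be only part of what the source reports. "The series", "measured", "known", "first", "only" and "open" are said of these compounds alone.

Compound 1: `COc1cc(-c2cc(/C=C/C(=O)c3ccc(N)cc3)[nH]n2)cc(OC)c1OC` — -61%
Compound 2: `COc1ccc(C(=O)/C=C/c2cc(-c3cc(OC)c(OC)c(OC)c3)n[nH]2)cc1` — -83%

Both were tested in a functional assay on ACHN cells (Homo sapiens) for cytotoxicity, read by sulforhodamine B assay, with a stated time of 48 h, tested at 10 uM; on this read-out higher numbers stand for a weaker effect at the one concentration tested and lower numbers for a stronger effect. Going by the values given here, compound 2 stands lowest of the two numbers, and its only neighbour is compound 1; the single measured step, a number 22 percentage points lower from compound 1 to compound 2 (beyond the scatter), altered the 4-methoxyphenyl that now leaves again. Compound 3, `COc1cc(-c2cc(/C=C/C(=O)c3ccc(F)c(F)c3)[nH]n2)cc(OC)c1OC`, differs from compound 2 by 3,4-difluorophenyl in place of 4-methoxyphenyl on a carbonyl carbon. Among the compounds with values here, no measured step exchanges a methoxy-bearing ring for a difluoro-bearing one, so the direction cannot be read from the data; the one step that touched this ring was modest, so a step of similar modest size is expected, here tentatively toward a weaker effect, as a number 13 percentage points higher from compound 2 to compound 3 (beyond the scatter). Compound 3 is therefore estimated at -70%, within a range from -95% to -40%.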

Compound 3, a percentage reported as activity, at one concentration (the size of the read-out at that concentration, not a potency): 2%
Beside the measured number, compound 3's estimate is 72 percentage points below it, and the stated range ends below it.
By their numbers in this assay, from the lowest: compound 2; then compound 1; then compound 3.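

The ring on the carbonyl carbon matters far more than the first pair suggested: 4-methoxyphenyl and 4-aminophenyl differ only modestly, whereas 3,4-difluorophenyl gives a number 85 percentage points higher from compound 2 to compound 3 (beyond the scatter) and a number 63 percentage points higher from compound 1 to compound 3 (beyond the scatter). In this assay, compound 3 reads 2%, so with the rest of the molecule shared, this one ring separates a strong effect from a much weaker one at the single concentration tested. Nothing measured here explains why the difluoro ring behaves so differently.

The compounds shown leave open whether the weaker effect needs both fluorines or would also appear with one, as in 4-fluorophenyl. They also leave open how a plain phenyl or a 4-hydroxyphenyl on the carbonyl carbon would read, and where such rings would fall in this range.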